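Swapping the ester for a nitrile on a thiazole core

The source may hold more compounds than are shown below. What is called first, only, known or untested is meant among the compounds shown, and "the series" means these compounds.

Compound 1 `CCOC(=O)c1sc(N2CCCC2)nc1Cl`: 78000 nM
Compound 2 `O=C(c1ccccc1)c1sc(N2CCCC2)nc1Cl`: > 100000 nM

Going by the values given here, in a functional assay on PC-3 cells (Homo sapiens) for cytotoxicity, read by MTT assay, with a stated time of 72 h (a lower number here means a stronger inhibitor, a higher number a weaker inhibitor), compound 1 gives 78000 nM, the only number reported. Compound 2 reaches only the assay limit of > 100000 nM. Among the compounds with values here, the one measured step, an at least 1.2-fold higher number from compound 1 to compound 2 (0.10 log units; that floor lies within the scatter), reaches the limit of > 100000 nM in this assay, at which 1 of the 2 values shown sits, and is at its floor within the scatter. Compound 3 `N#Cc1sc(N2CCCC2)nc1Cl` differs from compound 1 by cyano in place of ethoxycarbonyl on an aromatic carbon. Within the data shown here, no measured step tests this exchange on the shared core, so no shift beyond the scatter is expected, and a limit is quite possible. Compound 3 is therefore estimated at 90000 nM (range 30000 nM to 300000 nM), a step of a 1.2-fold higher number from compound 1 to compound 3 (0.06 log units; within the scatter).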

Compound 3, half-maximal inhibitory concentration: > 100000 nM
Compound 3 was reported as a limit (the forecaster's own chance of this, stated with the estimate: 45%); middle value at least 1.1-fold (0.04 log units) from the limit.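

On this aromatic carbon, exchanging ethoxycarbonyl for cyano in this assay gives an at least 1.2-fold higher number from compound 1 to compound 3 (0.10 log units; that floor lies within the scatter) and so brings no measurable gain in strength, even though the carbonyl is gone. Going by these compounds, the value of compound 3 is a limit, so the true size of this step remains unknown. With this second limit, the upper end of the assay now bounds most of the values:  the limit of > 100000 nM in this assay, at which 2 of the 3 values shown sit.

On these data alone, whether any group at this position can give a lower number than compound 1 stays open. A carboxylic acid or a primary amide here would test this.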